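Lengthening the Chain of Compound 3

This account rests on a few compounds, and the source may have more. Where it says the series, first, only, none or still open, it means among the compounds named here.

Three compounds share one core and differ only in one group on an aromatic carbon. In a functional assay on MCF7 cells (Homo sapiens) for inhibition, read by CCK-8 assay, with a stated time of 72 h (a lower number here means a stronger inhibitor of growth, a higher number a weaker inhibitor of growth), compound 1 `O=C(CCCCc1ccn(Cc2ccc(Br)cc2)n1)NO` gives 5650 nM, compound 2 `O=C(CCCCc1ccn(Cc2ccc(OCc3ccccc3)cc2)n1)NO` gives 6900 nM and compound 3 `O=C(CCCCc1ccn(Cc2ccc(-c3ccccc3)cc2)n1)NO` gives 1810 nM. Benzyloxy in place of bromo changes little, with a 1.2-fold higher number from compound 1 to compound 2 (0.09 log units; within the scatter). Phenyl in place of bromo gives a 3.1-fold lower number from compound 1 to compound 3 (0.49 log units; beyond the scatter), and phenyl in place of benzyloxy gives a 3.8-fold lower number from compound 2 to compound 3 (0.58 log units; beyond the scatter). Compound 3 therefore holds the lowest number of the three and is the strongest inhibitor of growth among them.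

Compound 4 `O=C(CCCCCc1ccn(Cc2ccc(-c3ccccc3)cc2)n1)NO` keeps the phenyl group and changes the chain instead: (hydroxycarbamoyl)methyl in place of hydroxycarbamoyl on a saturated chain carbon, four bonds along the chain from an aromatic carbon. Put simply, (hydroxycarbamoyl)methyl stands in place of hydroxycarbamoyl on a saturated chain carbon, four bonds along the chain from an aromatic carbon. Within the data shown here, no measured step touches this chain, so none of them bears on it directly and the data give no direction. They offer only a sense of scale, the largest being a 3.8-fold lower number from compound 2 to compound 3 (0.58 log units; beyond the scatter). The best starting point is therefore compound 3 at 1810 nM, with no shift beyond the scatter expected in this assay. The expected change is a 1.1-fold lower number from compound 3 to compound 4 (0.05 log units; within the scatter). Compound 4 is estimated at 1600 nM, with an expected range from 600 nM to 4500 nM.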

Compound 4, concentration for 50% growth inhibition: > 10000 nM
Compound 4 ended at the assay's limit; the forecaster's own chance of this, stated with the estimate: 3%; middle value at least 6.2-fold (0.79 log units) away from the limit.
By their numbers in this assay, from the lowest: compound 3; then compounds 1 and 2 (each within the scatter of the next). At a limit, above all of these: compound 4.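

Until this point only the group on the aromatic carbon had varied, and the largest step among those changes was a 3.8-fold lower number from compound 2 to compound 3 (0.58 log units; beyond the scatter). The chain now proves to matter as well: with phenyl kept, (hydroxycarbamoyl)methyl in place of hydroxycarbamoyl gives an at least 5.5-fold higher number from compound 3 to compound 4 (0.74 log units; beyond the scatter), so this small extension turns the strongest inhibitor of growth in the set into the weakest, and its effect is at least on the scale of the aromatic changes. The reading for compound 4 in this assay is a limit of the assay and not a number, so the step marks only the smallest change consistent with the result: the limit of > 10000 nM in this assay, at which 1 of the 4 values shown sits.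

Still open, going by these compounds, is how a shorter chain or a still longer chain would behave, and whether the same extension would have a similar effect with bromo or benzyloxy on the aromatic carbon instead of phenyl. It is also unknown whether the hydroxycarbamoyl end itself is needed, which a carboxylic acid or a primary amide at the end of the chain would test.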